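From Fluoro to Acetyl on the Pendant Phenyl

The compounds below may be only part of what the source reports. "The series", "measured", "known", "first", "only" and "open" are said of these compounds alone.

compound 1 `Brc1cn2ccnc2c(-c2ccc3ncn(C4CCCCC4)c3c2)n1` — 24.2%
compound 2 `Fc1ccc(-c2cn3ccnc3c(-c3ccc4ncn(C5CCCCC5)c4c3)n2)cc1` — 15.8%

In a functional assay on MDA-MB-231 cells (Homo sapiens) for inhibition, read by sulforhodamine B assay, with a stated time of 48 h, tested at 10 uM (on this read-out higher numbers stand for more inhibition at the one concentration tested (going by the name of the read-out) and lower numbers for less inhibition), compound 1 gives 24.2% and compound 2 gives 15.8%. Compound 2 stands at the lower of the two numbers, separated from compound 1 only by a number 8.4 percentage points lower from compound 1 to compound 2 (within the scatter). Compound 3 `CC(=O)c1ccc(-c2cn3ccnc3c(-c3ccc4ncn(C5CCCCC5)c4c3)n2)cc1` differs from compound 2 by acetyl in place of fluoro on an aromatic carbon. For the measured compounds named here, the only known step, from compound 1 to compound 2, exchanged a different group at a different place and stayed small, so it bears only loosely here. No step beyond the scatter is expected in this assay. The estimate for compound 3 is 18%, between 5% and 35%, a change of a number 2.2 percentage points higher from compound 2 to compound 3 (within the scatter).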

Compound 3, a percentage reported as inhibition, at one concentration (the size of the read-out at that concentration, not a potency): 7.65%
For compound 3 the middle estimate is 10.4 percentage points above the measured one, and the stated range covers the measured number.
By their numbers in this assay, from the lowest: compounds 3, 2 and 1 (each within the scatter of the next, the first and the last beyond it).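

Placing acetyl where fluoro stood, on the aromatic carbon para to a large group, gives (a number 8.2 percentage points lower from compound 2 to compound 3 (within the scatter)) in this assay, so this change cannot be told apart from no change at all. For the compounds shown here, replacing bromo with 4-acetylphenyl gives the first step that passes the scatter (a number 16.6 percentage points lower from compound 1 to compound 3 (beyond the scatter)), though it remains modest and alters the molecule at a different level than the fluoro-to-acetyl swap. Nothing available explains either step. On these data alone, whether an amine or a carboxylic acid at this same place would read differently remains open. Three compounds also cannot establish a trend for groups on this phenyl ring.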